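Removing the Fluorine from the Ketone Aryl Ring

The source may report more compounds than this note shows. Statements on the series, on what has been measured and on what is new or still open speak of the compounds shown alone.

Measured so far in a functional assay on PC-3 cells (Homo sapiens) for cytotoxicity, read by MTT assay, with a stated time of 48 h; a lower number here means a stronger inhibitor, a higher number a weaker inhibitor:
Compound 1 `COc1cc(-c2nnc3n2NC(c2ccco2)C(C(=O)c2ccccc2C)S3)cc(OC)c1OC` gives 88400 nM.
Compound 2 `COc1cc(-c2nnc3n2NC(c2ccco2)C(C(=O)c2ccc(F)cc2)S3)cc(OC)c1OC` gives 27700 nM.

Compound 2 holds the lower of the two numbers, which here means the stronger inhibitor of the pair. Among the compounds with values here, the only step seen so far is a 3.2-fold lower number from compound 1 to compound 2 (0.50 log units; beyond the scatter), brought by 4-fluorophenyl in place of 2-methylphenyl on the carbonyl carbon.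

Compound 3 `COc1cc(-c2nnc3n2NC(c2ccco2)C(C(=O)c2ccccc2)S3)cc(OC)c1OC` differs from compound 2 by hydrogen in place of fluoro on an aromatic carbon. Within the data shown here, that measured step swapped one substituted phenyl for another and did move the number beyond the scatter, but no measured step removes the fluoro alone, so it bears only loosely on this change. A step of about the size of the scatter is expected, a 1.4-fold higher number from compound 2 to compound 3 (0.14 log units; within the scatter), tilted if anything toward a weaker inhibitor. Compound 3 is estimated at 38000 nM in this assay, with a range from 13000 nM to 110000 nM.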

Compound 3, half-maximal inhibitory concentration: 64300 nM
Compound 3: the middle estimate sits 1.7-fold (0.23 log units) below what was measured; low and high end bracket the measured number.
By their numbers in this assay, from the lowest: compound 2; then compounds 3 and 1 (each within the scatter of the next).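

Taking the fluoro off alone gives a 2.3-fold higher number from compound 2 to compound 3 (0.37 log units; beyond the scatter) in this assay and so ties a step beyond the scatter to this one atom on the ring, rather than to a swap of whole substituted phenyl groups. Taking the methyl off compound 1 gives a 1.4-fold lower number from compound 1 to compound 3 (0.14 log units; within the scatter) and so does not separate the benzoyl of compound 3 from the 2-methylbenzoyl of compound 1, which leaves the fluoro as the only ring change here that separates two compounds. Nothing available explains why the fluoro matters at this position.

As far as these compounds go, it remains open whether the step is particular to fluoro or would also appear with chloro, methoxy or an amine at the same place on the ring. The compounds shown also cannot tell whether a fluoro elsewhere on this ring would act the same way.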